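A few compounds are considered here, and "the series" means these few. Any claim that something is new, unique, unknown or untested is made for them only; others in the source may bear on it.

Measured compounds in an in vitro functional assay on cells for agonist activity at Bombesin receptor subtype-3 (Mus musculus), read by luminescence and calcium flux; on this read-out higher numbers stand for an effect only at larger amounts of compound and lower numbers for an effect already at smaller amounts:
compound 1 `COc1ccc(Cc2cnc(CCc3ccc(-c4ccccc4C(=O)O)cc3)[nH]2)cc1` gives 513 nM
compound 2 `Cc1cccc(Cc2cnc(CCc3ccc(-c4ccccc4C(=O)O)cc3)[nH]2)c1` gives 75 nM

Among the measured compounds shown here, compound 2 stands lowest of the two numbers so far in this assay; its only neighbour is compound 1, and the step of a 6.8-fold lower number from compound 1 to compound 2 (0.84 log units; beyond the scatter) separates the two. That step changes two things at once, the group on the pendant ring and its place on that ring, so it does not isolate either change.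

Compound 3 `N#Cc1cccc(Cc2cnc(CCc3ccc(-c4ccccc4C(=O)O)cc3)[nH]2)c1` is not yet measured. It differs from compound 2 by cyano in place of methyl on an aromatic carbon. For the measured compounds named here, the one measured step bears on this only loosely: it shows that the substituent on this ring can move the number in this assay beyond the scatter, but no measured pair compares cyano with methyl at the same place. The direction cannot be read from the data; the expected step of a 2.0-fold higher number from compound 2 to compound 3 (0.30 log units; within the scatter) is therefore taken as small, with a wide range to either side. For compound 3 the estimate in this assay is 150 nM, expected to fall between 40 nM and 600 nM.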

Compound 3, half-maximal effective concentration: 20 nM
Compound 3: middle estimate off by 7.5-fold (0.88 log units), on the high side, and the stated range ends above it.
By their numbers in this assay, from the lowest: compound 3; then compound 2; then compound 1.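

In this assay, among the compounds shown here, the step of a 3.8-fold lower number from compound 2 to compound 3 (0.57 log units; beyond the scatter) is the first comparison of two groups at one and the same place on this ring, meta to a large group, and it shows that exchanging methyl for cyano there moves the number beyond the scatter with the rest of the structure unchanged. For the compounds shown here, the 3-cyanophenyl group also gives the widest gap so far, a 26-fold lower number from compound 1 to compound 3 (1.41 log units; beyond the scatter), although that step replaces 4-methoxyphenyl and so changes both the group and its place on the ring without separating the two. No supporting evidence is available to explain the difference between cyano and methyl at this position.

The compounds shown leave open how chlorine, trifluoromethyl or an amide would read at this same place, and whether cyano would keep its effect at another place on the ring. They also leave open how much of the gap from 4-methoxyphenyl belongs to the group and how much to its place, as no methoxy group is shown at the place held by cyano in compound 3.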